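Swapping the Sulfonyl Aryl Group for a Benzyl Group

The compounds below may be only part of what the source reports. "The series", "measured", "known", "first", "only" and "open" are said of these compounds alone.

Compound 3 `COc1ccc(/C=C(\C(=O)c2ccc(Br)cc2)S(=O)(=O)c2ccc(C)cc2)cc1` holds the lowest number of the three measured compounds in a functional assay on DU-145 cells (Homo sapiens) for inhibition, read by trypan blue exclusion, with a stated time of 96 h (a lower number here means a stronger inhibitor of growth, a higher number a weaker inhibitor of growth), where compound 3 gives 1000 nM. Compound 2 `COc1ccc(/C=C(\C(=O)c2ccc(Br)cc2)S(=O)(=O)c2ccc(Br)cc2)cc1` gives 25000 nM, and compound 1 `COc1ccsc1/C=C(\C(=O)c1ccc(Br)cc1)S(=O)(=O)Cc1ccc(Cl)cc1` gives 50000 nM. For the measured compounds named here, the single step measured in one place, a 25-fold lower number from compound 2 to compound 3 (1.40 log units; beyond the scatter), shows that the group attached to the sulfonyl sulfur can move the number a long way. Compound 4 `COc1ccc(/C=C(\C(=O)c2ccc(Br)cc2)S(=O)(=O)Cc2ccc(Cl)cc2)cc1` differs from compound 3 at that same position: 4-chlorobenzyl in place of 4-methylphenyl on a sulfonyl sulfur. Going by the values given here, no measured step covers this exact exchange. Compound 1, which differs from compound 4 in another part of the structure, carries the same 4-chlorobenzyl on its sulfonyl sulfur, and compound 1 gives only 50000 nM, a weak result that hints this group may sit toward the weaker end. A rise in the number beyond the scatter is therefore expected for compound 4, estimated at 15000 nM with a range from 3000 nM to 60000 nM. The implied step a 15-fold higher number from compound 3 to compound 4 (1.18 log units; beyond the scatter) is an expectation rather than a measurement.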

Compound 4, concentration for 50% growth inhibition: 25000 nM
Estimate against measurement, compound 4: 1.7-fold (0.22 log units) below; the measured number falls inside the stated range.
By their numbers in this assay, from the lowest: compound 3; then compounds 2, 4 and 1 (each within the scatter of the next).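

In this assay the exchange of 4-methylphenyl for 4-chlorobenzyl on the sulfonyl sulfur gives a 25-fold higher number from compound 3 to compound 4 (1.40 log units; beyond the scatter) and so puts a direct reading on this change. Against 4-bromophenyl the same group gives no change at the digits printed from compound 2 to compound 4 (within the scatter) and thus leaves 4-methylphenyl alone among the three groups read at this position on this core. The exchange of 3-methoxythiophen-2-yl for 4-methoxyphenyl on a double-bonded chain carbon gives a 2.0-fold lower number from compound 1 to compound 4 (0.30 log units; within the scatter) and does not separate these two compounds.

The compounds shown do not tell whether the lower number of compound 3 follows the methyl group or the ring sitting directly on sulfur, a question that 4-methylbenzyl or 4-chlorophenyl would address, and they leave an amine or a carboxylic acid on that ring open. Nothing available bears on why the numbers fall as they do.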